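Fluoro in Place of Methyl on the Phenyl Group

The source may hold more compounds than are shown below. What is called first, only, known or untested is meant among the compounds shown, and "the series" means these compounds.

Of the compounds shown here, three sharing one core have been tested in a functional assay on A549 cells (Homo sapiens) for cytotoxicity, read by MTT assay, with a stated time of 72 h; on this read-out lower numbers stand for stronger inhibition and higher numbers for weaker inhibition. Compound 1 `Cc1cc(=O)n(-c2ccc(Br)cc2F)nc1C(=O)Nc1ccc(Oc2ncnc3sccc23)cc1` gives 12800 nM in this assay, and compound 2 `Cc1cc(=O)n(-c2ccccc2OC(F)(F)F)nc1C(=O)Nc1ccc(Oc2ncnc3sccc23)cc1` gives 15500 nM. For compound 3 `Cc1ccc(-n2nc(C(=O)Nc3ccc(Oc4ncnc5sccc45)cc3)c(C)cc2=O)cc1` the assay returns only a limit, > 40000 nM. Compound 3 thus stands at the weak end of the three: the step of an at least 3.1-fold higher number from compound 1 to compound 3 (0.49 log units; beyond the scatter) and the step of an at least 2.5-fold higher number from compound 2 to compound 3 (0.41 log units; beyond the scatter) both run beyond the scatter, whereas a 1.2-fold higher number from compound 1 to compound 2 (0.08 log units; within the scatter) does not.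

Compound 4 `Cc1cc(=O)n(-c2ccc(F)cc2)nc1C(=O)Nc1ccc(Oc2ncnc3sccc23)cc1` has not yet been measured. It differs from compound 3 by fluoro in place of methyl on an aromatic carbon. Within the data shown here, no measured step in this set exchanges a methyl for a fluoro; the three available steps replace the whole group on the aromatic nitrogen. The two steps that end at the limit, an at least 3.1-fold higher number from compound 1 to compound 3 (0.49 log units; beyond the scatter) and an at least 2.5-fold higher number from compound 2 to compound 3 (0.41 log units; beyond the scatter), both move away from phenyls bearing halogen or trifluoromethoxy and onto 4-methylphenyl. Compound 4 carries a fluoro on its phenyl, as compound 1 carries bromo and fluoro. A modest step back in the direction of compound 1 is therefore expected for compound 4, an at least 1.6-fold lower number from compound 3 to compound 4 (0.20 log units; that floor lies within the scatter). Compound 4 is estimated at 25000 nM, within a range from 8000 nM to 60000 nM, and the assay may again report only a limit.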

Compound 4, half-maximal inhibitory concentration: 7050 nM
Compound 4: the middle estimate sits 3.5-fold (0.55 log units) above what was measured; the measured number lies below the stated range.
By their numbers in this assay, from the lowest: compounds 4, 1 and 2 (each within the scatter of the next, the first and the last beyond it). At a limit, above all of these: compound 3.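

Fluoro in place of methyl on the phenyl group, para to a large group, is the first change in this set confined to a single atom, and in this assay it gives an at least 5.6-fold lower number from compound 3 to compound 4 (0.75 log units; beyond the scatter), so this one exchange is enough to bring the compound off the limit to a measured value. The single fluoro of 4-fluorophenyl also keeps the level of the more heavily substituted phenyl, with a 1.8-fold lower number from compound 1 to compound 4 (0.26 log units; within the scatter), while the same group separates from 2-(trifluoromethoxy)phenyl, with a 2.2-fold lower number from compound 2 to compound 4 (0.34 log units; beyond the scatter). Compound 3 is held at a limit, so the first of these steps gives only a floor for the size of the change: the limit of > 40000 nM in this assay, at which 1 of the 4 values shown sits.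

From the compounds shown here alone, whether the step comes from the fluoro itself or from the loss of the methyl remains open, as does how a chloro, a methoxy or an amine at this place on the phenyl would read. Going by these compounds, it is also open whether the same exchange would read alike on another core or in any read-out other than this assay.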